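Aryl versus cyclopropyl on the triazole of a furanone scaffold

A few compounds are considered here, and "the series" means these few. Any claim that something is new, unique, unknown or untested is made for them only; others in the source may bear on it.

Measured compounds:
Compound 1, `CCCCCc1ccc(-c2cn(C[C@H](O)[C@H]3OC(=O)C(OCc4ccccc4)=C3OCc3ccccc3)nn2)cc1`, in a functional assay on MCF7 cells (Homo sapiens) for antiproliferative activity, read by MTT assay, with a stated time of 72 h (a lower number here means a stronger inhibitor, a higher number a weaker inhibitor), gives 9010 nM.
Compound 2, `CC(C)(C)OC(=O)N1CCN(C(=S)SCc2cn(C[C@H](O)[C@H]3OC(=O)C(OCc4ccccc4)=C3OCc3ccccc3)nn2)CC1`, in this assay reaches only the limit > 100000 nM.
Compound 3, `O=C1O[C@H]([C@@H](O)Cn2cc(C3CC3)nn2)C(OCc2ccccc2)=C1OCc1ccccc1`, in this assay gives 25900 nM.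

Compound 3 stands at the highest of the two numbers in this assay; its nearest neighbour is compound 1, and the step of a 2.9-fold higher number from compound 1 to compound 3 (0.46 log units; beyond the scatter) separates them. Among the compounds with values here, compound 2 gives a limit rather than a number, described by the limit of > 100000 nM in this assay, at which 1 of the 3 values shown sits, and so contributes no measured step.

Compound 4, `COc1ccc(-c2cn(C[C@H](O)[C@H]3OC(=O)C(OCc4ccccc4)=C3OCc3ccccc3)nn2)cc1`, differs from compound 3 by 4-methoxyphenyl in place of cyclopropyl on an aromatic carbon. Within the data shown here, the only measured step that bears on this change is a 2.9-fold higher number from compound 1 to compound 3 (0.46 log units; beyond the scatter), in which an aryl group on that aromatic carbon was exchanged for cyclopropyl and the number rose modestly. Compound 4 reverses that exchange in kind, putting an aromatic ring back in place of cyclopropyl, though with a methoxy group instead of the pentyl chain of compound 1. Compound 4 is therefore expected to show a modest move back toward the number of compound 1, a step of a 2.4-fold lower number from compound 3 to compound 4 (0.37 log units; beyond the scatter) in this assay. The estimate for compound 4 in this assay is 11000 nM, with a range from 4000 nM to 35000 nM.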

Compound 4, half-maximal inhibitory concentration: 99700 nM
The estimate for compound 4 lay 9.1-fold (0.96 log units) below the measured number; measured number above the stated range.
By their numbers in this assay, from the lowest: compound 1; then compound 3; then compound 4. At a limit, above all of these: compound 2.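

An aromatic ring on this carbon of the triazole does not by itself lower the number: in this assay, 4-methoxyphenyl in place of cyclopropyl gives a 3.8-fold higher number from compound 3 to compound 4 (0.59 log units; beyond the scatter), so the earlier exchange of aryl for cyclopropyl cannot be read as a general preference for aryl. Within the data shown here, what the ring carries counts for more than the ring alone, since methoxy in place of pentyl gives an 11-fold higher number from compound 1 to compound 4 (1.04 log units; beyond the scatter), a large step and larger than the one separating either aryl compound from the cyclopropyl compound. Compound 3 thus lies between compound 1 and compound 4, and aryl against cyclopropyl at this position has no single direction among the compounds shown.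

As far as these compounds go, whether a propyl or an octyl chain, or an amine, in place of the pentyl or methoxy group would place the number between those of compound 1 and compound 4 stays open, as does the position of an unsubstituted phenyl. Compound 2 adds no step to this picture, as its entry is a limit and not a number: the limit of > 100000 nM in this assay, at which 1 of the 4 values shown sits.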